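This account rests on a few compounds, and the source may have more. Where it says the series, first, only, none or still open, it means among the compounds named here.

- Compound 1 `Cc1cc(Nc2cc(-c3ccccc3)[nH]n2)n2nc(SCC(=O)c3ccccc3)nc2n1`: 4450 nM
- Compound 2 `C=CCSc1nc2nc(C)cc(Nc3cc(-c4ccccc4)[nH]n3)n2n1`: > 50000 nM (a limit, not a number)

Both results come from a functional assay on PC-9 cells (Homo sapiens) for inhibition, read by MTT assay, with a stated time of 72 h; on this read-out higher numbers stand for weaker inhibition and lower numbers for stronger inhibition. Compound 2 sits at the limit of > 50000 nM in this assay, at which 1 of the 2 values shown sits. Compound 3 `COc1ccc(CSc2nc3nc(C)cc(Nc4cc(-c5ccccc5)[nH]n4)n3n2)cc1` differs from compound 2 in one place: 4-methoxyphenyl in place of vinyl on a saturated chain carbon bound to a sulfur. Here 4-methoxyphenyl stands in place of vinyl on a saturated chain carbon bound to a sulfur.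

Among the compounds with values here, one measured step bears on this change: an at least 11-fold higher number from compound 1 to compound 2 (1.05 log units; beyond the scatter). It was made at the same place, with vinyl in place of benzoyl. Compound 3 carries an aromatic ring on that chain again, as compound 1 4450 nM does, so a large step towards stronger inhibition is expected in this assay. This expectation rests on a single step, so it is uncertain. The estimated step is an at least 5.5-fold lower number from compound 2 to compound 3 (0.74 log units; beyond the scatter). For compound 3 the expected value is 9000 nM, with an estimated range from 2500 nM to 35000 nM.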

Compound 3, half-maximal inhibitory concentration: 8110 nM
Beside the measured number, compound 3's estimate is 1.1-fold (0.05 log units) above it; the measured number falls inside the stated range.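

In this assay, putting 4-methoxyphenyl in place of vinyl on this saturated chain carbon bound to a sulfur gives an at least 6.1-fold lower number from compound 2 to compound 3 (0.78 log units; beyond the scatter). Putting 4-methoxyphenyl in place of benzoyl gives a 1.8-fold higher number from compound 1 to compound 3 (0.26 log units; within the scatter), so these two aromatic groups cannot be told apart here, and the carbonyl of benzoyl is not required for activity at this level. The first step is only a lower bound on the true size of the change, because compound 2 has a limit and not a number: the limit of > 50000 nM in this assay, at which 1 of the 3 values shown sits.

The compounds shown leave open whether an aromatic ring is what counts at this place, or whether a longer saturated chain such as hexyl would do as well. On these data alone, how a plain benzyl group or a chain ending in a carboxylic acid would read in this assay also stays open.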